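Trifluoromethyl for Trifluoromethoxy on a Sulfonyl Aryl Ring

The source may report more compounds than this note shows. Statements on the series, on what has been measured and on what is new or still open speak of the compounds shown alone.

Of the compounds shown here, three sharing one core have been measured. Compound 1 `O=C1C=CC2(C=C1)OCC(=O)N2S(=O)(=O)c1ccc(OC(F)(F)F)cc1` carries a trifluoromethoxy group; in a functional assay on HeLa cells (Homo sapiens) for inhibition, read by sulforhodamine B assay, with a stated time of 74 h (on this read-out lower numbers stand for stronger inhibition and higher numbers for weaker inhibition), compound 1 gives > 10000 nM, which is a limit of the assay rather than a number (the limit of > 10000 nM in this assay, at which 1 of the 3 values shown sits). Compound 3 `O=C1C=CC2(C=C1)OCC(=O)N2S(=O)(=O)c1ccc(C(F)(F)F)cc1` differs by trifluoromethyl in place of trifluoromethoxy on an aromatic carbon and in this assay compound 3 gives 770 nM, so the step of an at least 12-fold lower number from compound 1 to compound 3 (1.11 log units; beyond the scatter). Compound 2 `O=C1C=CC2(C=C1)OCC(=O)N2S(=O)(=O)c1ccccc1OC(F)(F)F` has the same atoms as compound 1 joined differently; how the two cores differ is not broken down here. In this assay compound 2 gives 140 nM.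

Compound 4 `O=C1C=CC2(C=C1)OCC(=O)N2S(=O)(=O)c1ccccc1C(F)(F)F` is not yet measured. It differs from compound 2 by trifluoromethyl in place of trifluoromethoxy on an aromatic carbon. The place is not identical to the earlier change: there the group sat para to a large group, here ortho to a large group, so this is the same kind of change rather than the same one. An expected step of a 1.8-fold lower number from compound 2 to compound 4 (0.24 log units; within the scatter) rests on compound 3, whose step was an at least 12-fold lower number from compound 1 to compound 3 (1.11 log units; beyond the scatter), tempered by the different place. Compound 4 is therefore estimated at 80 nM, within 20 nM to 400 nM.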

Compound 4, half-maximal inhibitory concentration: 20 nM
Estimate against measurement, compound 4: 4.0-fold (0.60 log units) above, within the range that was stated.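

Trifluoromethyl in place of trifluoromethoxy gives a lower number on both cores in this assay, and on the core of compound 2, where the group sits ortho to a large group, the new step is a 7.0-fold lower number from compound 2 to compound 4 (0.85 log units; beyond the scatter). Compound 1 gives > 10000 nM, which is a limit of the assay and not a number, so the earlier step has a bound rather than an exact size: the limit of > 10000 nM in this assay, at which 1 of the 4 values shown sits. Two pairs show that the direction of the change was shared here, not that it will hold on other cores, and they do not settle whether its size carried over: the same change on two cores in this assay, an at least 12-fold lower number (1.11 log units; beyond the scatter) from compound 1 to compound 3 and a 7.0-fold lower number (0.85 log units; beyond the scatter) from compound 2 to compound 4; the limit leaves it open whether they differ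

The compounds shown leave open how a smaller or differently built group at the same place, such as methyl, methoxy, chlorine or a nitrile, would compare with these two fluorinated groups. Also open, from the compounds shown here alone, is whether the same change would give the same direction in any test other than this assay.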